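The source may report more compounds than this note shows. Statements on the series, on what has been measured and on what is new or still open speak of the compounds shown alone.

Among the compounds with values here, in an ADME assay on HEK-293T cells (Homo sapiens) for inhibition, read by CCK-8 assay, with a stated time of 48 h, tested at 20 uM (on this read-out higher numbers stand for more inhibition of growth at the one concentration tested and lower numbers for less inhibition of growth), compound 1 `N#C/C(=C\c1ccccc1OS(=O)(=O)c1ccccc1[N+](=O)[O-])C(=O)Nc1nnc(Cc2ccc(F)cc2)s1` gives 6% and compound 2 `N#C/C(=C\c1ccccc1OS(=O)(=O)c1ccc(Cl)cc1)C(=O)Nc1nnc(Cc2ccc(F)cc2)s1` gives 6% in the same test, so compound 2 stands level with compound 1 on the numbers so far. Within the data shown here, the only measured step shows no change at the digits printed from compound 1 to compound 2 (within the scatter) for 4-chlorophenyl in place of 2-nitrophenyl on a sulfonyl sulfur. Compound 3 `Cc1ccc(Cc2nnc(NC(=O)/C(C#N)=C/c3ccccc3OS(=O)(=O)c3ccc(Cl)cc3)s2)cc1` keeps the sulfonyl group of compound 2 and differs from it at one place: methyl in place of fluoro on an aromatic carbon is the count, and in words the change is methyl in place of fluoro on an aromatic carbon, para to a large group, or 4-fluorobenzyl to 4-methylbenzyl. Among the measured compounds shown here, no measured step covers this place, so the one step available bears on the change only loosely and gives no direction. Taking compound 2 at 6% as the starting point, no shift beyond the scatter is expected in this assay and the estimated step reads a number 1 percentage points higher from compound 2 to compound 3 (within the scatter) on this scale. The estimated value for compound 3 is 7% with an expected range from 0% to 20% in this test.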

Compound 3, percent growth inhibition at one concentration: 8%
Compound 3: the middle estimate sits 1 percentage points below what was measured; the measured number falls inside the stated range.
By their numbers in this assay, from the lowest: compounds 1, 2 and 3 (each within the scatter of the next).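

In this assay, methyl in place of fluoro on an aromatic carbon, para to a large group, gives a number 2 percentage points higher from compound 2 to compound 3 (within the scatter), the swap being 4-fluorobenzyl to 4-methylbenzyl. Within the data shown here, this is the first reading at this position: compounds 1 and 2 share the 4-fluorobenzyl group and differ only at the group on the sulfonyl sulfur, so the benzyl end now joins the sulfonyl end as a place where one swap stays within the scatter of this read-out. No supporting measurement bears on this result, so the reading stands as a bare number without explanation.

From the compounds shown here alone, the fluoro and methyl pair covers only a narrow slice of this position, so it remains open whether an amine, a carboxylic acid or a longer chain such as propyl in the same place would also stay within the scatter in this assay. Also open, going by these compounds, is whether the reading at this position carries over when the 4-chlorophenyl on the sulfonyl sulfur is replaced by the 2-nitrophenyl of compound 1.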